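Fluorophenyl for bromophenyl on the triazole arm

The compounds below may be only part of what the source reports. "The series", "measured", "known", "first", "only" and "open" are said of these compounds alone.

Measured compounds in a functional assay on MIA PaCa-2 cells (Homo sapiens) for inhibition, read by MTT assay, with a stated time of 48 h, tested at 10 uM; a higher number here means more inhibition of growth at the concentration tested, a lower number less inhibition of growth:
Compound 1 `C#CCOc1ccc(/C=C/C(=O)c2ccc(Br)cc2)cc1` gives 34%
Compound 2 `C#CCOc1ccc(/C=C/C(=O)c2ccc(OC)cc2)cc1` gives 32%
Compound 3 `O=C(/C=C/c1ccc(OCc2cn(Cc3cccc(Br)c3)nn2)cc1)c1ccc(Br)cc1` gives 43%

Compound 3 has the highest of the three numbers in this assay. Its nearest neighbour is compound 1, and the gap between them lies within the scatter; the gap to compound 2 lies beyond it. Among the measured compounds shown here, no measured pair separates the two by only one change, so only the values themselves can be compared.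

Compound 4 `O=C(/C=C/c1ccc(OCc2cn(Cc3ccc(F)cc3)nn2)cc1)c1ccc(Br)cc1` differs from compound 3 in one place: 4-fluorophenyl in place of 3-bromophenyl on a saturated chain carbon bound to an aromatic nitrogen. For the measured compounds named here, the single measured step, a number 2 percentage points lower from compound 1 to compound 2 (within the scatter), concerns a substituent on the aryl ketone and not the benzyl group on the triazole, so it does not bear on this change. Nothing measured speaks to swapping one halogenated benzyl for another at this place. The expectation is therefore a step of a number 3 percentage points lower from compound 3 to compound 4 (within the scatter) in this assay, none beyond the scatter. Compound 4 is accordingly estimated at 40%, with a range from 25% to 55%.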

Compound 4, percent growth inhibition at one concentration: 32%
Compound 4: middle estimate off by 8 percentage points, on the high side; the measured number falls inside the stated range.
By their numbers in this assay, from the lowest: compounds 2, 4, 1 and 3 (each within the scatter of the next, the first and the last beyond it).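

In this assay, the place on a saturated chain carbon bound to an aromatic nitrogen proves responsive to the aryl group it carries: 4-fluorophenyl in place of 3-bromophenyl gives a number 11 percentage points lower from compound 3 to compound 4 (beyond the scatter) in this series. Beside the one earlier step, a number 2 percentage points lower from compound 1 to compound 2 (within the scatter) on the aryl ketone, this is the first single change shown to exceed the scatter, although both groups have the same heavy-atom count and neither has a hydrogen-bond donor or acceptor. No evidence at hand explains the step.

The halogen and its ring position change together here, leaving open which of them carries the step; 4-bromophenyl or 3-fluorophenyl would separate the two. Also open, from the compounds shown here alone, is how this place would respond to a benzyl group bearing an amine or a carboxylic acid.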